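The compounds below may be only part of what the source reports. "The series", "measured", "known", "first", "only" and "open" are said of these compounds alone.

Measured in an ADME assay on MT4 cells (Homo sapiens) for cytotoxicity, read by MTT assay, with a stated time of 5 days; a higher number here means that more compound is tolerated, a lower number that less compound is tolerated:
compound 1 `O=C(CSc1ncnn1-c1ccc(Cl)cc1Cl)Nc1ccccc1F`: 38400 nM
compound 2 `Cc1ccc(NC(=O)CSc2ncnn2-c2ccc(Cl)cc2Cl)c([N+](=O)[O-])c1`: > 285000 nM

Compound 2 stands at the limit of > 285000 nM in this assay, at which 1 of the 2 values shown sits, which is a limit and not a number. Among the compounds with values here, no step between measured compounds that differ in one place is available for this series. Next comes compound 3 `Cc1ccc(NC(=O)CSc2ncnn2-c2ccc(Cl)cc2Cl)c(Br)c1`, with bromo in place of nitro on an aromatic carbon, ortho to a large group and meta to a methyl group: bromo in place of nitro on an aromatic carbon. A downward step in this assay, beyond the scatter, is expected, although another result at a limit remains possible. Within the data shown here, this expectation leans on compound 1, the only compound so far with a real number, 38400 nM. The expected change is an at least 4.0-fold lower number from compound 2 to compound 3 (0.60 log units; beyond the scatter). Compound 3 is estimated at 70000 nM, with an expected range from 20000 nM to 250000 nM.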

Compound 3, half-maximal cytotoxic concentration: > 184000 nM
Compound 3 gave a limit, no number; the forecaster's own chance of this, stated with the estimate: 35%; middle value at least 2.6-fold (0.41 log units) away from the limit.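

In this assay, compound 3 also gives a limit and not a number: the limit of > 184000 nM in this assay, at which 1 of the 3 values shown sits.
Its step from compound 2 cannot be read, so the series still gives no size for bromo in place of nitro at this position, ortho to a large group and meta to a methyl group. Within the data shown here, the 2-bromo-4-methylphenyl group in place of 2-fluorophenyl on the amide-type nitrogen does give the first readable step, an at least 4.7-fold higher number from compound 1 to compound 3 (0.68 log units; beyond the scatter).

That step carries the bromo and the methyl group together, and the compounds shown do not separate the share of each. Also open, on these data alone, is whether an amine or a carboxylic acid in place of bromo at this position would give a real number rather than a limit.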